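A few compounds are considered here, and "the series" means these few. Any claim that something is new, unique, unknown or untested is made for them only; others in the source may bear on it.

Measured in a functional assay on OVCAR-3 cells (Homo sapiens) for inhibition, read by sulforhodamine B assay, with a stated time of 48 h; on this read-out lower numbers stand for stronger inhibition of growth and higher numbers for weaker inhibition of growth:
- compound 1 `Cc1ccc(C2=NN(c3ccc(S(C)(=O)=O)cc3)C(=O)CC2)cc1`: 360 nM
- compound 2 `Cc1cc(O)ccc1C1=NN(c2ccc(S(C)(=O)=O)cc2)C(=O)CC1`: 3410 nM

Among the compounds with values here, of these two compounds, compound 2 has the higher number and is the weaker growth inhibitor, with compound 1 as its only neighbour. The next compound to consider is compound 3 `CCc1ccc(C2=NN(c3ccc(S(C)(=O)=O)cc3)C(=O)CC2)cc1`, which has not yet been measured. It differs from compound 2 as follows: 4-ethylphenyl in place of 4-hydroxy-2-methylphenyl on a carbon with a double bond to nitrogen. Put simply, 4-ethylphenyl stands in place of 4-hydroxy-2-methylphenyl on a carbon with a double bond to nitrogen.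

Within the data shown here, only one measured step bears on this change: a 9.5-fold higher number from compound 1 to compound 2 (0.98 log units; beyond the scatter). That step replaced 4-methylphenyl with 4-hydroxy-2-methylphenyl, and its size lies beyond the usual scatter. Compound 3 lacks the hydroxy group, as compound 1 does, so the move from compound 2 largely runs that step in reverse. Among the measured compounds shown here, no measured compound carries 4-ethylphenyl, however, so the effect of ethyl rather than methyl remains unknown, and one step is a thin basis for a forecast. The expected change is a 6.8-fold lower number from compound 2 to compound 3 (0.83 log units; beyond the scatter), towards a lower number. Compound 3 is estimated at 500 nM, with an expected range of 150 nM to 1600 nM.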

Compound 3, concentration for 50% growth inhibition: 930 nM
Estimate against measurement, compound 3: 1.9-fold (0.27 log units) below, and the stated range covers the measured number.
By their numbers in this assay, from the lowest: compound 1; then compound 3; then compound 2.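

In this assay there is now a second reading of this position: a 3.7-fold lower number from compound 2 to compound 3 (0.56 log units; beyond the scatter), so swapping 4-hydroxy-2-methylphenyl for 4-ethylphenyl regains part of the growth inhibition, though not all of it. Within the data shown here, the new compound also gives the first look at a small change to the alkyl group alone, as methyl in place of hydrogen on the saturated chain carbon bound to an aromatic carbon gives a 2.6-fold higher number from compound 1 to compound 3 (0.41 log units; beyond the scatter) and lies beyond the usual scatter, so even this small extension of 4-methylphenyl counts in this assay and compound 1 remains the strongest of the three. Nothing available here explains why either step has the size it has.

Compound 2 differs from compound 1 by both a hydroxy group and an extra methyl on the aromatic ring, so these compounds cannot show how much of its weaker inhibition belongs to each. From the compounds shown here alone, how a longer chain such as propyl, a methoxy group, an amine or a chlorine atom would behave on this aromatic ring also remains open.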